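The source may hold more compounds than are shown below. What is called first, only, known or untested is meant among the compounds shown, and "the series" means these compounds.

Of the compounds shown here, three of a shared core have been tested in a functional assay on the whole organism for inhibition, with Rattus norvegicus as the target, read by paw edema, with stated times of 30 min and 2 h, at a dose of 10 mg/kg by the oral route; on this read-out higher numbers stand for more inhibition at the one dose given (going by the name of the read-out) and lower numbers for less inhibition. Compound 1, `O=C1N=C(C2C(=O)c3ccccc3C2=O)CC(c2ccccc2)N1`, gives 33%. Compound 2, `COc1ccc(C2CC(C3C(=O)c4ccccc4C3=O)=NC(=O)N2)cc1`, which carries methoxy in place of hydrogen on an aromatic carbon, gives 21%, a step of a number 12 percentage points lower from compound 1 to compound 2 (beyond the scatter). Compound 3, `O=C1N=C(C2C(=O)c3ccccc3C2=O)CC(/C=C/c2ccccc2)N1`, with 2-phenylethenyl in place of phenyl on a saturated ring carbon, gives 32%, a step of a number 1 percentage points lower from compound 1 to compound 3 (within the scatter). Compound 3 thus stands second highest of the three numbers, within the scatter of compound 1 and beyond the scatter above compound 2, the step being a number 11 percentage points higher from compound 2 to compound 3 (beyond the scatter).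

Compound 4, `O=C1N=C(C2C(=O)c3ccccc3C2=O)CC(c2ccc(Cl)cc2)N1`, differs from compound 3 by 4-chlorophenyl in place of 2-phenylethenyl on a saturated ring carbon. The step from compound 1 to compound 3 shows that phenyl and 2-phenylethenyl give numbers within the scatter of each other, so the return to an aromatic ring on its own is not expected to move the number. Among the measured compounds shown here, the step from compound 1 to compound 2 shows that a substituent on that aromatic ring lowered the number modestly, but no compound carries chlorine, so the size of any such effect is not known here. Compound 4 is therefore expected to sit near compound 1 or somewhat lower, a step of a number 5 percentage points lower from compound 3 to compound 4 (within the scatter), with an estimated value of 27% in a range from 14% to 40%.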

Compound 4, a percentage reported as inhibition, in the whole organism at one dose (the size of the read-out at that dose, not a potency): 19%
Compound 4: middle estimate off by 8 percentage points, on the high side; low and high end bracket the measured number.
By their numbers in this assay, from the lowest: compounds 4 and 2 (each within the scatter of the next); then compounds 3 and 1 (each within the scatter of the next).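

In this assay, chloro in place of hydrogen on the aromatic carbon gives a number 14 percentage points lower from compound 1 to compound 4 (beyond the scatter), while chloro in place of methoxy gives a number 2 percentage points lower from compound 2 to compound 4 (within the scatter), so the drop seen with methoxy is no longer a single case: both substituted phenyl groups on the saturated ring carbon sit at a similar level, under the plain phenyl. The change of 2-phenylethenyl to 4-chlorophenyl gives a number 13 percentage points lower from compound 3 to compound 4 (beyond the scatter), which shows that the earlier match between phenyl and 2-phenylethenyl does not extend to every aromatic group at this position. Nothing among the available data explains why either substituent lowers the inhibition of paw edema at this dose.

From the compounds shown here alone, only methoxy and chloro have been seen on this aromatic ring, and both at the same ring position, so it remains open whether the lower number would hold for a methyl group, an amine or a carboxylic acid there, or for chloro at another ring carbon. Going by these compounds, it is also open how a longer chain or a simple alkyl group would behave on the saturated ring carbon, and whether a substituent on the ring of 2-phenylethenyl would have the same effect as on phenyl.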